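Aortic inhibition: swapping a bromophenyl for a dimethoxyphenyl

The compounds below may be only part of what the source reports. "The series", "measured", "known", "first", "only" and "open" are said of these compounds alone.

Compound 1 `CCOc1nc(-c2cc3ccccc3o2)cc(-c2ccc(Cl)cc2Cl)c1C#N` gives 442000 nM in a functional assay on aorta (strain Wistar) for inhibition, with Thoracic aorta (Rattus norvegicus) as the target; a higher number here means a weaker inhibitor, a lower number a stronger inhibitor.
Compound 2 `CCOc1nc(-c2cc3ccccc3o2)cc(-c2ccc(Br)cc2)c1C#N` gives 227000 nM in this assay.

For the measured compounds named here, compound 2 has the lowest of the two numbers, but the only measured step, a 1.9-fold lower number from compound 1 to compound 2 (0.29 log units; within the scatter), lies within the scatter, so the two compounds cannot be told apart. Compound 3 `CCOc1nc(-c2cc3ccccc3o2)cc(-c2ccc(OC)cc2OC)c1C#N` differs from compound 2 by 2,4-dimethoxyphenyl in place of 4-bromophenyl on an aromatic carbon. Going by the values given here, no measured step touches the same change, so nothing beyond the scatter is expected: the estimate for compound 3 is 250000 nM (range 80000 nM to 800000 nM), a step of a 1.1-fold higher number from compound 2 to compound 3 (0.04 log units; within the scatter).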

Compound 3, half-maximal inhibitory concentration: 488000 nM
For compound 3 the middle estimate is 2.0-fold (0.29 log units) below the measured one; the measured number falls inside the stated range.
By their numbers in this assay, from the lowest: compounds 2, 1 and 3 (each within the scatter of the next, the first and the last beyond it).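

For the compounds shown here, at this position, opposite the ring nitrogen, replacing 4-bromophenyl with 2,4-dimethoxyphenyl gives the first step beyond the scatter in this assay, though a modest one (a 2.1-fold higher number from compound 2 to compound 3 (0.33 log units; beyond the scatter)). Against 2,4-dichlorophenyl, the same group gives no readable difference (a 1.1-fold higher number from compound 1 to compound 3 (0.04 log units; within the scatter)), so compound 1 and compound 3 cannot be told apart. No evidence at hand accounts for either step.

All three groups here are phenyl rings, so the compounds shown leave open how an amine or a carboxylic acid would read at this position.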